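Aminooxy-to-amino swap on the methylated core

The source may hold more compounds than are shown below. What is called first, only, known or untested is meant among the compounds shown, and "the series" means these compounds.

Measured so far:
compound 1, `CN(CCCN)C[C@H]1O[C@@H](n2cnc3c(N)ncnc32)[C@H](O)[C@@H]1O`, 500000 nM
compound 2, `CN(CCCCON)C[C@H]1O[C@@H](n2cnc3c(N)ncnc32)[C@H](O)[C@@H]1O`, 18 nM
compound 3, `Cc1nc2c(N)ncnc2n1[C@@H]1O[C@H](CN(C)CCCCON)[C@@H](O)[C@H]1O`, 5 nM

All three were run in an assay on isolated protein for inhibition of S-adenosylmethionine decarboxylase proenzyme (Homo sapiens); a lower number here means a stronger inhibitor, a higher number a weaker inhibitor. Compound 3 gives the lowest number of the three; compound 2 stands nearest to it and compound 1 furthest.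

Two structural changes run through the series. The first, from compound 2 to compound 1, is amino in place of (aminooxy)methyl on a saturated chain carbon, three bonds along the chain from an amine nitrogen; it made a 28000-fold higher number from compound 2 to compound 1 (4.44 log units; beyond the scatter). The second, from compound 2 to compound 3, is methyl in place of hydrogen on an aromatic carbon; it made a 3.6-fold lower number from compound 2 to compound 3 (0.56 log units; beyond the scatter). The cores of compound 2 and compound 3 thus differ only by that methyl.

Compound 4, `Cc1nc2c(N)ncnc2n1[C@@H]1O[C@H](CN(C)CCCN)[C@@H](O)[C@H]1O`, has not yet been measured in this assay. It differs from compound 3 by amino in place of (aminooxy)methyl on a saturated chain carbon, three bonds along the chain from an amine nitrogen. Among the compounds with values here, this is the same change as the one from compound 2 to compound 1, at the same place; the two pairs differ only in the core, as just told.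

Within the data shown here, on the single earlier instance, that change made a 28000-fold higher number from compound 2 to compound 1 (4.44 log units; beyond the scatter). If it carries over onto the core of compound 3, the step from compound 3 to compound 4 in this assay is expected to be about a 28000-fold higher number from compound 3 to compound 4 (4.45 log units; beyond the scatter), resting on compound 3 at 5 nM and on the earlier pair. Compound 4 is therefore estimated at 140000 nM, within a range of 20000 nM to 1000000 nM. Given compound 1 at 500000 nM, a number of that order for compound 4 would not be surprising.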

Compound 4, half-maximal inhibitory concentration: 70000 nM
Compound 4: the middle estimate sits 2.0-fold (0.30 log units) above what was measured; the measured number falls inside the stated range.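

On the core of compound 3, amino in place of (aminooxy)methyl made a 14000-fold higher number from compound 3 to compound 4 (4.15 log units; beyond the scatter) in this assay and so repeated the step seen on the core of compound 2: the same change on two cores in this assay, a 28000-fold higher number (4.44 log units; beyond the scatter) from compound 2 to compound 1 and a 14000-fold higher number (4.15 log units; beyond the scatter) from compound 3 to compound 4, 2.0-fold (0.30 log units) apart, within the scatter of two such steps.
Read the other way round the same four compounds, methyl in place of hydrogen on an aromatic carbon made a 7.1-fold lower number from compound 1 to compound 4 (0.85 log units; beyond the scatter) and agrees with its earlier counterpart: the same change on two cores in this assay, a 3.6-fold lower number (0.56 log units; beyond the scatter) from compound 2 to compound 3 and a 7.1-fold lower number (0.85 log units; beyond the scatter) from compound 1 to compound 4, 2.0-fold (0.30 log units) apart, within the scatter of two such steps.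
Within compounds 1 to 4, then, each change keeps its size from one core to the other, but this rests on a single set of four compounds and does not show that the change would carry over onto any other core, nor why the step is so large.

The compounds shown leave open how the number moves with a shorter or longer chain carrying the aminooxy end, and whether the aminooxy group is matched by a hydrazine or a hydroxylamine at the chain end. They also leave open whether an ethyl group or a chlorine in place of the methyl on the aromatic carbon would sit on top of the amino swap in the same way.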